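Cytotoxicity notes on compounds 1 to 4

The source may hold more compounds than are shown below. What is called first, only, known or untested is meant among the compounds shown, and "the series" means these compounds.

Compound 1, `Cc1nc(C)c([C@H](OC(C)(C)C)C(=O)O)c(N2CCC(C)(C)CC2)c1-c1ccc(-c2ccccc2)cc1`, in a toxicity assay on MT2 cells (Homo sapiens) for cytotoxicity, read by XTT assay, with a stated time of 4 days (on this read-out lower numbers stand for higher toxicity in this test and higher numbers for lower toxicity in this test), gives >= 20000 nM, a limit of the assay.
Compound 2, `Cc1nc(C)c([C@H](OC(C)(C)C)C(=O)O)c(N2CCC(C)(C)CC2)c1-c1ccc(OCCc2ccc(C#N)cc2)cc1`, in this assay gives >= 33500 nM, a limit of the assay.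
Compound 3, `Cc1cc(CCOc2ccc(-c3c(C)nc(C)c([C@H](OC(C)(C)C)C(=O)O)c3N3CCC(C)(C)CC3)cc2)ccc1F`, in this assay gives >= 33500 nM, a limit of the assay.

Compound 3 therefore stands only at a limit, as do the other two measured compounds; every value shown sits at the limit of >= 20000 nM in this assay, at which 1 of the 3 values shown sits, or (the limit of >= 33500 nM in this assay, at which 2 of the 3 values shown sit). The measured steps a step that the two limits leave unreadable from compound 1 to compound 2, a step that the two limits leave unreadable from compound 1 to compound 3 and a step that the two limits leave unreadable from compound 2 to compound 3 are all unreadable for this reason.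

Compound 4, `Cc1nc(C)c([C@H](OC(C)(C)C)C(=O)O)c(N2CCC(C)(C)CC2)c1-c1ccc(SCCc2ccc(F)cc2)cc1`, differs from compound 3 by (2-(4-fluorophenyl)ethyl)sulfanyl in place of 2-(4-fluoro-3-methylphenyl)ethoxy on an aromatic carbon. No readable step bears on this change, and no value below the limits has been seen, so no step beyond the scatter is expected; the step of a number no higher from compound 3 to compound 4 (the limit leaves the size open) is the estimate. Compound 4 is expected to give 33500 nM, within 15000 nM to 70000 nM, most probably again as a limit.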

Compound 4, half-maximal cytotoxic concentration: >= 32000 nM
Compound 4: only a limit was reported; the forecaster's own chance of this, stated with the estimate: 85%; the middle value is on the limit's open side.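

Compound 4 stands only at a limit in this assay, and its steps from compound 1, compound 2 and compound 3 cannot be read. The compounds shown leave open the half-maximal cytotoxic concentration of each compound and whether any of these changes alters it.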